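The source may report more compounds than this note shows. Statements on the series, on what has been measured and on what is new or still open speak of the compounds shown alone.

- compound 1 `COc1ccc(C(=O)Nc2sc3c(c2C(N)=O)CCCC3)cc1`: 1300 nM
- compound 2 `NC(=O)c1c(NC(=O)c2ccc(Cl)cc2)sc2c1CCCC2`: 1400 nM

In a functional assay on MV4-11 cells (Homo sapiens) for antiproliferative activity (on this read-out lower numbers stand for stronger inhibition and higher numbers for weaker inhibition), compound 2 gives 1400 nM and lies within the scatter of compound 1. Compound 3 `CC(=O)c1ccc(C(=O)Nc2sc3c(c2C(N)=O)CCCC3)cc1` has acetyl in place of chloro on an aromatic carbon, para to a large group: acetyl in place of chloro on an aromatic carbon. Going by the values given here, the only measured step at this place is a 1.1-fold higher number from compound 1 to compound 2 (0.03 log units; within the scatter), with chloro in place of methoxy. Among the compounds with values here, no measured compound carries acetyl, so this is thin evidence, and no shift beyond the scatter is expected. The expected change is a 1.1-fold higher number from compound 2 to compound 3 (0.03 log units; within the scatter). For compound 3 the estimated value is 1500 nM, with an expected range from 550 nM to 4000 nM.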

Compound 3, half-maximal inhibitory concentration: 1800 nM
Beside the measured number, compound 3's estimate is 1.2-fold (0.08 log units) below it, within the range that was stated.
By their numbers in this assay, from the lowest: compounds 1, 2 and 3 (each within the scatter of the next).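

Acetyl on this aromatic carbon, para to a large group, brings more heavy atoms than chloro and a hydrogen-bond acceptor, yet in this assay the result is a 1.3-fold higher number from compound 2 to compound 3 (0.11 log units; within the scatter) and a 1.4-fold higher number from compound 1 to compound 3 (0.14 log units; within the scatter). Three different groups at this position therefore give numbers that cannot be told apart, which a single step between two groups could not show. Nothing available explains this tolerance.

Going by these compounds, whether an amine or a carboxylic acid here would move the number beyond the scatter remains open, as do changes elsewhere on the shared core.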